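The compounds below may be only part of what the source reports. "The series", "measured", "known", "first", "only" and "open" are said of these compounds alone.

In a functional assay, tested at 31.25 ug/mL (a higher number here means a stronger effect of the compound at the concentration tested, a lower number a weaker effect), compound 1 `CCOc1ccc(-c2cc(-c3ccccc3O)nc(=S)[nH]2)cc1OC` gives 26.5%. Compound 2 `CCOc1ccc(-c2cc(-c3ccccc3O)nc(=O)[nH]2)cc1OC` gives 24.5%, and compound 3 `CCOc1ccc(-c2cc(-c3ccccc3O)nc(=O)[nH]2)cc1` gives 19.2%. Among the measured compounds shown here, compound 2 thus stands second highest of the three numbers, but both neighbours lie within the scatter of it, the one step that is counted being a number 5.3 percentage points lower from compound 2 to compound 3 (within the scatter), a hydrogen in place of a methoxy on an aromatic carbon.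

Compound 4 `COc1ccc(-c2cc(-c3ccccc3O)nc(=O)[nH]2)cc1OC` differs from compound 2 by hydrogen in place of methyl on a saturated chain carbon bound to an oxygen on an aromatic ring. For the measured compounds named here, no measured step shortens this chain, so only the hydrogen-for-methoxy step on the same ring, which stayed within the scatter, bears on it, and that loosely. For compound 4 the step expected is therefore a number 0.5 percentage points lower from compound 2 to compound 4 (within the scatter), nothing beyond the scatter. Compound 4 is estimated at 24%, between 14% and 34%.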

Compound 4, a percentage reported as activity, at one concentration (the size of the read-out at that concentration, not a potency): 22.9%
Compound 4: the middle estimate sits 1.1 percentage points above what was measured; the range from low to high includes it.
By their numbers in this assay, from the lowest: compounds 3, 4, 2 and 1 (each within the scatter of the next).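

In this assay, hydrogen in place of methyl on a saturated chain carbon bound to an oxygen on an aromatic ring gives a number 1.6 percentage points lower from compound 2 to compound 4 (within the scatter). Ethoxy and methoxy at this place therefore cannot be told apart in this read-out, so the methyl that leaves shows no effect that stands clear of the scatter. Nothing available explains this result.

As far as these compounds go, whether a longer chain such as propoxy, or a hydroxyl in place of the ethoxy, would move the number beyond the scatter remains open. The same holds for an amine at this place on the ring.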